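From methoxycarbonyl to carboxy on compound 3

The compounds below may be only part of what the source reports. "The series", "measured", "known", "first", "only" and "open" are said of these compounds alone.

Measured in a functional assay on K562 cells (Homo sapiens) for antiproliferative activity, read by MTT assay, with a stated time of 48 h; on this read-out higher numbers stand for weaker inhibition and lower numbers for stronger inhibition:
compound 1 `COC(=O)[C@H](C)NC(=O)c1ccc(Oc2nc3ccccc3nc2C)cc1`: 45500 nM
compound 2 `Cc1nc2ccccc2nc1Oc1ccc(C(=O)N[C@@H](C)C(=O)O)cc1`: 28100 nM
compound 3 `COC(=O)[C@H](C)NC(=O)c1ccc(Oc2nc3ccccc3nc2NC(C)(C)C)cc1`: 42200 nM

The three values do not separate. Compound 3, at 42200 nM, lies within the scatter of both others, and its closest neighbour is compound 1: the link between them is a 1.1-fold lower number from compound 1 to compound 3 (0.03 log units; within the scatter). The open question concerns compound 4 `C[C@H](NC(=O)c1ccc(Oc2nc3ccccc3nc2NC(C)(C)C)cc1)C(=O)O`, reached from compound 3 by a single change, hydrogen in place of methyl on an oxygen next to a carbonyl group, or methoxycarbonyl to carboxy. The same change has been measured once, as a 1.6-fold lower number from compound 1 to compound 2 (0.21 log units; within the scatter). That single precedent gives no ground for expecting a shift beyond the scatter in this assay, though it points weakly towards a lower number. The expected change is therefore small, and the estimated step is a 1.5-fold lower number from compound 3 to compound 4 (0.16 log units; within the scatter). For compound 4 the estimated value is 29000 nM, with an expected range of 14000 nM to 58000 nM.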

Compound 4, half-maximal inhibitory concentration: 26400 nM
Estimate against measurement, compound 4: 1.1-fold (0.04 log units) above; the measured number falls inside the stated range.
By their numbers in this assay, from the lowest: compounds 4, 2, 3 and 1 (each within the scatter of the next).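

In this assay, the change from methoxycarbonyl to carboxy now has a second reading, a 1.6-fold lower number from compound 3 to compound 4 (0.20 log units; within the scatter), and it agrees with the reading on the core that carries methyl: the same change on two cores in this assay, a 1.6-fold lower number (0.21 log units; within the scatter) from compound 1 to compound 2 and a 1.6-fold lower number (0.20 log units; within the scatter) from compound 3 to compound 4, 1.0-fold (0.01 log units) apart, within the scatter of two such steps The change from methyl to (tert-butyl)amino on an aromatic carbon can now also be read among the carboxy compounds, a 1.1-fold lower number from compound 2 to compound 4 (0.03 log units; within the scatter), and it agrees with its reading among the methoxycarbonyl compounds: the same change on two cores in this assay, a 1.1-fold lower number (0.03 log units; within the scatter) from compound 1 to compound 3 and a 1.1-fold lower number (0.03 log units; within the scatter) from compound 2 to compound 4, 1.0-fold (0.01 log units) apart, within the scatter of two such steps Neither change moves the number beyond the scatter on either core, so these four compounds show no dependence of one change on the other.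

Going by these compounds, whether an amide in place of the carboxy group, or a longer chain on the amine in place of tert-butyl, would give a step beyond the scatter stays open. Also open, on these data alone, is whether the two matching steps to carboxy, each within the scatter, reflect a real shift.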